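This account rests on a few compounds, and the source may have more. Where it says the series, first, only, none or still open, it means among the compounds named here.

Measured compounds:
compound 1 `CC(/C=C/CC(C)CCCC(C)C)=C\C(=O)OC(C)(C)C` — 7.56
compound 2 `CCCOC(=O)/C=C(C)/C=C/CC(C)CCCC(C)(C)OC` — 6.08
compound 3 `COC(C)(C)CCCC(C)C/C=C/C(C)=C/C(=O)OC(C)(C)C` — 6.36

In a physicochemical assay for lipophilicity (on this read-out higher numbers stand for higher lipophilicity and lower numbers for lower lipophilicity), compound 1 gives 7.56, the highest of the three numbers. Nearest to it stands compound 3, with the step of a number 1.20 log units lower from compound 1 to compound 3 (beyond the scatter); furthest is compound 2, whose value 6.08 lies below both of the others.

Compound 4 `C=CCNC(=O)/C=C(C)/C=C/CC(C)CCCC(C)C` has not yet been measured in this assay. Relative to compound 1 the change is allylamino in place of tert-butoxy on a carbonyl carbon. Neither measured step covers this exchange. The step of a number 0.28 log units higher from compound 2 to compound 3 (within the scatter) varies only the alkyl on the oxygen next to the carbonyl and stays within the scatter, whereas a number 1.20 log units lower from compound 1 to compound 3 (beyond the scatter) is a large drop for adding methoxy on the saturated chain. For the measured compounds named here, compound 4 keeps the chain of compound 1 unchanged and alters the carbonyl terminus from tert-butoxycarbonyl to allylcarbamoyl, a change for which the set holds no direct precedent. A downward step beyond the scatter is nevertheless expected, estimated as a number 1.66 log units lower from compound 1 to compound 4 (beyond the scatter). For compound 4 the value in this assay is therefore expected to be about 5.9, likely between 5.2 and 6.6.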

Compound 4, partition coefficient: 5.23
The estimate for compound 4 lay 0.67 log units above the measured number, and the stated range covers the measured number.
By their numbers in this assay, from the lowest: compound 4; then compounds 2 and 3 (each within the scatter of the next); then compound 1.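

On the carbonyl carbon, allylamino in place of tert-butoxy gives a number 2.33 log units lower from compound 1 to compound 4 (beyond the scatter) in this assay, a large step with the chain of compound 1 unchanged. The earlier change at this end of the series, tert-butyl in place of propyl, gave only a number 0.28 log units higher from compound 2 to compound 3 (within the scatter) and stayed within the scatter, so the terminus is sensitive to the tert-butoxycarbonyl to allylcarbamoyl exchange in a way that exchange of the oxygen's alkyl group did not show. No measurement shown accounts for the size of this step.

The compounds shown leave open how much of the step belongs to the nitrogen and how much to the allyl group; a tert-butylamino or an allyloxy group on this carbonyl carbon would separate the two. Also open, as far as these compounds go, is whether methoxy on the saturated chain, which gave a number 1.20 log units lower from compound 1 to compound 3 (beyond the scatter), would act the same way alongside allylcarbamoyl.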